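Turning one stereocentre in compound 1

The compounds below may be only part of what the source reports. "The series", "measured", "known", "first", "only" and "open" are said of these compounds alone.

Compound 1 `CCCCCCCCNC[C@@H]1OC[C@H](N)[C@@H]1O`: 13800 nM
Compound 2 `CCCCCCCCCCCNC[C@@H]1OC[C@H](N)[C@@H]1O`: 3330 nM
Compound 3 `CCCCCCCCCCCCCCNC[C@@H]1OC[C@H](N)[C@H]1O`: 1990 nM

These numbers come from a functional assay on PC-3 cells (Homo sapiens) for antiproliferative activity, read by MTT assay, with a stated time of 72 h (a lower number here means a stronger inhibitor, a higher number a weaker inhibitor), and compound 1 has the highest of the three. Compound 4 `CCCCCCCCNC[C@@H]1OC[C@H](N)[C@H]1O` has not yet been measured. Set against compound 1, it shows the two compounds have the same atoms and bonds and differ only in configuration as drawn: 1 of 3 stereo elements differ; a stereocentre at a saturated ring carbon is drawn S in compound 1 and R in compound 4 and so has the same atoms and bonds. The two compounds differ only in configuration as drawn: a stereocentre at a saturated ring carbon is drawn S in compound 1 and R in compound 4.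

Among the compounds with values here, the one measured step, a 4.1-fold lower number from compound 1 to compound 2 (0.62 log units; beyond the scatter), changes the chain and not the configuration, so it gives no direct guide here. Compound 3 at 1990 nM has the configuration drawn for compound 4 but also a longer chain, so its value cannot separate the two changes. Within the data shown here, no measured pair isolates a change of configuration, and nothing points to a direction. No step beyond the scatter is therefore expected in this assay, although a real change remains possible and the range is kept wide. The expected change is a 1.3-fold lower number from compound 1 to compound 4 (0.10 log units; within the scatter) and it is only an estimate. The estimate for compound 4 is 11000 nM with an expected range from 4500 nM to 28000 nM in this assay.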

Compound 4, half-maximal inhibitory concentration: 13000 nM
Compound 4: middle estimate off by 1.2-fold (0.07 log units), on the low side, and the stated range covers the measured number.
By their numbers in this assay, from the lowest: compounds 3 and 2 (each within the scatter of the next); then compounds 4 and 1 (each within the scatter of the next).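

In this assay, drawing this saturated ring carbon as R rather than S gives a 1.1-fold lower number from compound 1 to compound 4 (0.03 log units; within the scatter), so on the shorter chain this stereocentre makes no difference that the assay can detect. The comparison is a clean one, as a single feature separates the pair: the fact that compounds 1 and 4 differ only in the configuration as drawn.

With the R configuration now held fixed, the chain can also be read on its own: hydrogen in place of hexyl on a saturated chain carbon, eight bonds along the chain from an amine nitrogen, gives a 6.5-fold higher number from compound 3 to compound 4 (0.82 log units; beyond the scatter), which runs the same way as the chain step among the S compounds, a 4.1-fold lower number from compound 1 to compound 2 (0.62 log units; beyond the scatter).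

As far as these compounds go, compound 2 and compound 3 differ in both chain and configuration, so it remains open whether this stereocentre also makes no detectable difference on a longer chain. The other two stereocentres stay the same across these compounds, and the compounds shown say nothing about a chain longer than that of compound 3, or about a carboxylic acid at the end of the chain.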